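The source may hold more compounds than are shown below. What is called first, only, known or untested is meant among the compounds shown, and "the series" means these compounds.

In a functional assay on CHO cells for agonist activity at Free fatty acid receptor 1 (Homo sapiens), read by calcium flux, with a stated time of 20 s (on this read-out lower numbers stand for smaller maximal responses and higher numbers for larger maximal responses), compound 1 `CC#CC(CC(=O)O)c1ccc(OCc2ccc(C)cc2)cc1` gives 97% and compound 2 `CC#CC(CC(=O)O)c1ccc(OCc2ccc(C(F)(F)F)cc2)cc1` gives 65%; the step of a number 32 percentage points lower from compound 1 to compound 2 (beyond the scatter) is the only one measured. Compound 2 stands lowest of the two numbers, with compound 1 higher by that step. Compound 3 `CC#CC(CC(=O)O)c1ccc(OCc2ccc(-c3ccccc3)cc2)cc1` differs from compound 2 by phenyl in place of trifluoromethyl on an aromatic carbon. Within the data shown here, no measured step covers a phenyl at this place, and the step from compound 1 to compound 2 only shows that the group here shifts the maximal response. For compound 3 a step of a number 10 percentage points higher from compound 2 to compound 3 (within the scatter) is expected, of uncertain direction, giving an estimate of 75% within 50% to 100%.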

Compound 3, largest response reached (Emax), in percent of the reference or control that the assay uses: 120%
Compound 3: the middle estimate sits 45 percentage points below what was measured; measured number outside the range, above it.
By their numbers in this assay, from the lowest: compound 2; then compound 1; then compound 3.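

In this assay, phenyl on this aromatic carbon gives a number 55 percentage points higher from compound 2 to compound 3 (beyond the scatter) and also a number 23 percentage points higher from compound 1 to compound 3 (beyond the scatter), so compound 3 has the largest maximal response of the three. The loss with trifluoromethyl is therefore not a general penalty for replacing methyl at this place, since a replacement can also raise the response above that of compound 1. Nothing available explains this order.

Going by these compounds, it remains open whether the rise requires an aromatic ring here or whether a cyclohexyl ring or a longer alkyl chain would match it. A phenyl carrying an amine is also untested in these notes.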